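Aromatic group swap from compound 3 to compound 4

The compounds below may be only part of what the source reports. "The series", "measured", "known", "first", "only" and "open" are said of these compounds alone.

In a functional assay on MOLT-4 cells (Homo sapiens) for inhibition, read by MTT assay, with a stated time of 72 h (on this read-out lower numbers stand for stronger inhibition and higher numbers for weaker inhibition), compound 1 `COc1cc(NC(C)CCCNC(=O)Nc2cccc(F)c2)c2ncccc2c1` gives 23000 nM, compound 2 `COc1cc(NC(C)CCCNC(=O)Nc2cccc(Cl)c2)c2ncccc2c1` gives 21000 nM and compound 3 `COc1cc(NC(C)CCCNC(=O)Nc2cccc(C(F)(F)F)c2)c2ncccc2c1` gives 20000 nM. Compound 3 therefore stands level with the other two, within the scatter. Compound 4 `COc1cc(NC(C)CCCNC(=O)Nc2ccc(Cl)cc2)c2ncccc2c1` carries 4-chlorophenyl in place of 3-(trifluoromethyl)phenyl on an amide-type nitrogen. The steps bearing on this change are the exchanges of the aromatic substituent: a 1.1-fold lower number from compound 1 to compound 2 (0.04 log units; within the scatter), a 1.2-fold lower number from compound 1 to compound 3 (0.06 log units; within the scatter) and a 1.1-fold lower number from compound 2 to compound 3 (0.02 log units; within the scatter), all within the scatter. Among the compounds with values here, no measured compound carries 4-chlorophenyl, so that part of the change remains untested. The expected step, no change at the digits printed from compound 3 to compound 4 (within the scatter), stays within the scatter, with no direction expected. Compound 4 is estimated at 20000 nM, with an expected range of 11000 nM to 35000 nM.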

Compound 4, half-maximal inhibitory concentration: 24000 nM
Beside the measured number, compound 4's estimate is 1.2-fold (0.08 log units) below it, and the stated range covers the measured number.
By their numbers in this assay, from the lowest: compounds 3, 2, 1 and 4 (each within the scatter of the next).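

In this assay, within the data shown here, 4-chlorophenyl in place of 3-chlorophenyl on the amide-type nitrogen gives a 1.1-fold higher number from compound 2 to compound 4 (0.06 log units; within the scatter) and is the first test of where chlorine sits on this ring, with no separation seen. The exchanges for 3-(trifluoromethyl)phenyl (a 1.2-fold higher number from compound 3 to compound 4 (0.08 log units; within the scatter)) and 3-fluorophenyl (a 1.0-fold higher number from compound 1 to compound 4 (0.02 log units; within the scatter)) leave all four compounds level as well. No evidence on hand bears on this flat result.

On these data alone, whether an amine or a carboxylic acid on this ring would separate from these compounds stays open. So does the effect of a longer chain between the shared core and the urea-type group.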